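The compounds below may be only part of what the source reports. "The series", "measured", "known", "first", "only" and "open" are said of these compounds alone.

Working notes on the series. Two compounds have a number in an assay on isolated protein for binding affinity to Alpha-1D adrenergic receptor (Rattus norvegicus), read by radioligand binding; a lower number here means a stronger inhibitor, a higher number a weaker inhibitor. Compound 1 `CCS(=O)(=O)Nc1ccc2c(c1)C(c1c[nH]cn1)CCC2` gives 339 nM in this assay. Compound 2 `Cn1cnc(C2CCCc3c(NS(C)(=O)=O)cccc32)c1` gives 1050 nM in this assay, which is the higher of the two numbers; the gap to compound 1 lies beyond the usual scatter, so compound 2 is the weaker binder of the pair. The two differ in more than one place, so nothing is known about what any single change contributes.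

Compound 3 `Cn1cncc1C1CCCc2c(NS(C)(=O)=O)cccc21` has not been measured. It keeps every atom of compound 2 and differs only in how the imidazole is attached: 1-methyl-1H-imidazol-5-yl in place of 1-methyl-1H-imidazol-4-yl on a saturated ring carbon. Within the data shown here, no pair of measured compounds isolates this change, so the size of the step is without precedent in this set. The expectation is that compound 3 will stay close to compound 2 in this assay, with the estimated step of a 1.1-fold lower number from compound 2 to compound 3 (0.02 log units; within the scatter) not beyond the scatter in either direction. On that basis compound 3 is estimated at 1000 nM in this assay, with a likely range from 300 nM to 3500 nM.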

Compound 3, inhibition constant: < 10000 nM
Compound 3 ended at the assay's limit; the forecaster's own chance of this, stated with the estimate: 5%; the middle value lies beyond the limit too.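

In this assay compound 3 gives < 10000 nM, which is a limit of the assay and not a number. Among these compounds, no step from compound 2 to compound 3 can be read, because the result sits at a limit: the limit of < 10000 nM in this assay, at which 1 of the 3 values shown sits. The compounds shown leave open what 1-methyl-1H-imidazol-5-yl in place of 1-methyl-1H-imidazol-4-yl contributes in this assay.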